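This account rests on a few compounds, and the source may have more. Where it says the series, first, only, none or still open, it means among the compounds named here.

Compound 1 `CC(C)N(C)c1nc(Cc2c(F)cccc2F)cc(=O)[nH]1`: 85000 nM
Compound 2 `Cc1c(Cc2c(F)cccc2F)nc(N(C)C)[nH]c1=O`: > 89000 nM, a limit
Compound 3 `CCN(C)c1nc(Cc2c(F)cccc2F)c(C)c(=O)[nH]1`: > 85000 nM, a limit

In an ADME assay on MT4 cells (Homo sapiens) for cytotoxicity, read by MTT assay, with a stated time of 4 days (on this read-out lower numbers stand for higher toxicity in this test and higher numbers for lower toxicity in this test), compound 1 is the only one of the three with a true number, 85000 nM. Compound 3 has no number and stands only at the limit of > 85000 nM in this assay, at which 1 of the 3 values shown sits. Compound 2 likewise gives only a limit, (the limit of > 89000 nM in this assay, at which 1 of the 3 values shown sits).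

Compound 4 `Cc1c(Cc2c(F)cccc2F)nc(N(C)C(C)C)[nH]c1=O` follows from compound 3 through a single change, (methyl in place of hydrogen on a saturated chain carbon bound to a nitrogen on an aromatic ring and a saturated chain carbon). This is methyl in place of hydrogen on a saturated chain carbon bound to a nitrogen on an aromatic ring and a saturated chain carbon, which reads as ethyl(methyl)amino to isopropyl(methyl)amino.

One measured step is of nearly the same kind, methyl in place of hydrogen on a saturated chain carbon bound to a nitrogen on an aromatic ring: a step that the two limits leave unreadable from compound 2 to compound 3. It offers no size to carry over, so no shift beyond the scatter is expected in either direction in this assay. The expected step is an at least 1.0-fold lower number from compound 3 to compound 4 (0.02 log units; that floor lies within the scatter). Among the measured compounds shown here, the estimate is anchored on the one true number, that of compound 1 at 85000 nM. For compound 4 the expected half-maximal cytotoxic concentration is 80000 nM, with an estimated range from 50000 nM to 95000 nM.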

Compound 4, half-maximal cytotoxic concentration: 79000 nM
Compound 4: the middle estimate sits 1.0-fold (0.01 log units) above what was measured; low and high end bracket the measured number.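

In this assay, among the compounds shown here, methyl in place of hydrogen on an aromatic carbon is the first change with a readable size (a 1.1-fold lower number from compound 1 to compound 4 (0.03 log units; within the scatter)), so this methyl can be set between two true numbers and does not carry the value beyond the scatter. The change from ethyl(methyl)amino to isopropyl(methyl)amino gives only a floor (an at least 1.0-fold lower number from compound 3 to compound 4 (0.03 log units; that floor lies within the scatter)), as does isopropyl in place of methyl on a nitrogen on an aromatic ring (an at least 1.1-fold lower number from compound 2 to compound 4 (0.05 log units; that floor lies within the scatter)), and neither floor lies beyond the scatter. Compound 3, the start of the first of these steps, stands as a limit and not a number: the limit of > 85000 nM in this assay, at which 1 of the 4 values shown sits.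

The step between compound 2 and compound 3 still cannot be read, so the compounds shown give no true size for a change from methyl to ethyl on that nitrogen. They also leave open whether a larger group there, such as cyclopentyl or a longer chain, or a chlorine atom or an amine in place of the methyl on the aromatic carbon, would move the number beyond the scatter.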